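From Isobutyl to Hexyl on the Shared Core

This account rests on a few compounds, and the source may have more. Where it says the series, first, only, none or still open, it means among the compounds named here.

Values in (a functional assay on MCF7 cells (Homo sapiens) for antiproliferative activity, with a stated time of 5 days; a lower number here means a stronger inhibitor, a higher number a weaker inhibitor):
- compound 1 `COc1ccc(-c2[nH]c3ccc(OC)cc3c2C=O)cc1` gives (180 nM)
- compound 2 `CCCCc1ccc2[nH]c(-c3ccc(OC)cc3)c(C=O)c2c1` gives (22 nM)
- compound 3 `COc1ccc(-c2[nH]c3ccc(CC(C)C)cc3c2C=O)cc1` gives (180 nM)

Compound 3 (180 nM) stands level with compound 1 (180 nM), and together they hold the highest number of the three. Compound 4 `CCCCCCc1ccc2[nH]c(-c3ccc(OC)cc3)c(C=O)c2c1` carries pentyl in place of isopropyl on a saturated chain carbon bound to an aromatic carbon. The closest measured step is (an 8.2-fold higher number from compound 2 to compound 3 (0.91 log units; beyond the scatter)), which brought in isopropyl in place of propyl. The change to compound 4 removes that isopropyl, so a step of similar size towards a lower number is expected in (this assay). The butyl step (an 8.2-fold lower number from compound 1 to compound 2 (0.91 log units; beyond the scatter)) points the same way. No chain longer than butyl has been measured, so the size remains uncertain. The estimated step is (a 6.0-fold lower number from compound 3 to compound 4 (0.78 log units; beyond the scatter)). Compound 4 is expected at (30 nM within 9 nM to 100 nM).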

Compound 4, half-maximal inhibitory concentration: 6 nM
Compound 4: the middle estimate sits 5.0-fold (0.70 log units) above what was measured, outside the stated range (below it).
By their numbers in this assay, from the lowest: compound 4; then compound 2; then compounds 1 and 3 (each within the scatter of the next).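

In this assay, extending the straight chain beyond butyl lowers the number further (a 3.7-fold lower number from compound 2 to compound 4 (0.56 log units; beyond the scatter)), so the gain at this position does not end with butyl. Hexyl also stands well clear of the branched isobutyl (a 30-fold lower number from compound 3 to compound 4 (1.48 log units; beyond the scatter)) and of methoxy (a 30-fold lower number from compound 1 to compound 4 (1.48 log units; beyond the scatter)), which shows how much room this position leaves between its chains. Nothing available explains these steps.

From the compounds shown here alone, whether a longer chain such as octyl would lower the number further or reverse the trend remains open. So does whether a terminal amine on the hexyl chain would be tolerated.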